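Pyridyl sulfonyl in place of methoxyphenyl on a pyrrole core

The source may hold more compounds than are shown below. What is called first, only, known or untested is meant among the compounds shown, and "the series" means these compounds.

Compounds so far and their inhibition:
compound 1 `CNCc1cc(-c2cccnc2)n(S(=O)(=O)c2ccccc2)c1`, 4%
compound 2 `CNCc1cc(-c2ccc(F)cc2)n(S(=O)(=O)c2ccc(C)cc2)c1`, 86%
compound 3 `CNCc1cc(-c2cccnc2F)n(S(=O)(=O)c2cccc(OC)c2)c1`, 92%

In a functional assay on the whole organism (strain Jcl:SD) for inhibition, with Rattus norvegicus as the target, with stated times of 3 min and 3 h, at a dose of 1 mg/kg by the intravenous route (on this read-out lower numbers stand for less inhibition and higher numbers for more inhibition at the one dose given (going by the name of the read-out)), compound 1 gives 4%, compound 2 gives 86%, and compound 3 gives 92%. Among these three numbers compound 3 stands highest. Its gap to compound 2 lies within the scatter, so the two cannot be placed in order; its gap to compound 1 is large and lies well beyond the scatter. No two of the three measured compounds differ in one place only, so no single step can be read off from them.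

Compound 4 `CNCc1cc(-c2cccnc2F)n(S(=O)(=O)c2ccc(OC)nc2)c1` is the next compound. It differs from compound 3 in one place: 6-methoxypyridin-3-yl in place of 3-methoxyphenyl on a sulfonyl sulfur. Every other part of the molecule, including the fluorinated pyridine on the core and the aminomethyl chain, stays as in compound 3.

Going by the values given here, nothing among the measured compounds reports a change of this kind on the sulfonyl sulfur, so the expectation rests on the closeness of compounds 2 and 3 alone. The step from compound 3 to compound 4 is expected to be a number 12 percentage points lower from compound 3 to compound 4 (beyond the scatter), a modest drop that may well stay within the scatter. Compound 4 is therefore estimated at 80%, with a range from 45% to 97% in this assay.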

Compound 4, a percentage reported as inhibition, in the whole organism at one dose (the size of the read-out at that dose, not a potency): 97%
Compound 4: the middle estimate sits 17 percentage points below what was measured, within the range that was stated.
By their numbers in this assay, from the lowest: compound 1; then compounds 2, 3 and 4 (each within the scatter of the next, the first and the last beyond it).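

In this assay, placing 6-methoxypyridin-3-yl in place of 3-methoxyphenyl on a sulfonyl sulfur gives a number 5 percentage points higher from compound 3 to compound 4 (within the scatter) and so leaves the two compounds without an order. This is the first change among the compounds shown that can be read at a single place, and it shows that a six-membered aromatic ring with one hetero atom can stand on this sulfur in place of a ring of carbon only, with one more hydrogen-bond acceptor by count, without a step beyond the scatter at the one dose given. Nothing at hand explains why the read-out holds across this change.

Going by these compounds alone, this single step covers only two closely matched groups on the sulfonyl sulfur, so it remains open whether the read-out would hold with a dimethylamino group or a carboxylic acid in place of the methoxy group on the 6-methoxypyridin-3-yl ring. Also open, going by these compounds, is how a longer chain in place of the methylaminomethyl chain on the shared core would fare with this sulfonyl group in place.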